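A few compounds are considered here, and "the series" means these few. Any claim that something is new, unique, unknown or untested is made for them only; others in the source may bear on it.

Measured compounds:
Compound 1, `OC[C@]1(c2ccc(F)cc2)NC[C@H](O)[C@H]1O`: 0%
Compound 2, `Cc1ccc([C@]2(CO)NC[C@@H](O)[C@@H]2O)cc1`: 0%
Compound 3, `OC[C@]1(c2ccc(O)cc2)NC[C@H](O)[C@H]1O`: 0%

In an assay on isolated protein for inhibition of tissue alpha-L-fucosidase (Bos taurus), tested at 1000 uM (on this read-out lower numbers stand for less inhibition and higher numbers for more inhibition at the one concentration tested (going by the name of the read-out)), compound 1 gives 0%, compound 2 gives 0% and compound 3 gives 0%. Compound 3 thus stands level with compounds 1 and 2; none of the three shows inhibition at the concentration tested. Among the compounds with values here, the one measured step that differs in a single place, no change at the digits printed from compound 1 to compound 3 (within the scatter), concerns the same aromatic position that is altered in the step now to be examined.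

Compound 4, `Cc1ccc([C@@]2(CO)NC[C@H](O)[C@H]2O)cc1`, differs from compound 3 by methyl in place of hydroxy on an aromatic carbon. Compound 2 carries the same methyl group on that carbon and also gives 0%. Since exchanging fluoro for hydroxy at this position left the read-out unchanged within the scatter, and since the methyl-bearing compound 2 is also at the floor of the read-out, no step beyond the scatter is expected in this assay for no change at the digits printed from compound 3 to compound 4 (within the scatter). Compound 4 is accordingly estimated at 0%, with a range from -8% to 10%.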

Compound 4, a percentage reported as inhibition, at one concentration (the size of the read-out at that concentration, not a potency): 3.3%
For compound 4 the middle estimate is 3.3 percentage points below the measured one; the range from low to high includes it.
By their numbers in this assay, from the lowest: compounds 1, 2, 3 and 4 (each within the scatter of the next).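

In this assay, methyl in place of hydroxy on this aromatic carbon gives a number 3.3 percentage points higher from compound 3 to compound 4 (within the scatter), and methyl in place of fluoro gives a number 3.3 percentage points higher from compound 1 to compound 4 (within the scatter), so the read-out does not separate methyl from either earlier group. The new information concerns configuration: inverting all the stereocentres gives a number 3.3 percentage points higher from compound 2 to compound 4 (within the scatter), so at this one concentration the read-out does not separate these mirror images either. This step isolates drawn configuration, with the substituent held constant: the fact that compounds 2 and 4 differ only in the configuration as drawn

As far as these compounds go, it remains open whether an amine, a carboxylic acid or a longer chain on this aromatic carbon would give a step beyond the scatter in this assay. With all four compounds within the scatter of one another, the data also cannot show whether substituent or configuration matters for this enzyme under conditions that give clear inhibition.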